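Replacing Ethyl With an Oxadiazole on the Shared Core

The source may hold more compounds than are shown below. What is called first, only, known or untested is meant among the compounds shown, and "the series" means these compounds.

- Compound 1 `CC(=O)NCc1ccc2c(c1)nc(Cn1c(=O)n(C(C)C)c3ccccc31)n2CCC(C)C`: 178000 nM
- Compound 2 `CCc1ccc2c(c1)nc(Cn1c(=O)n(C(C)C)c3ccccc31)n2CCC(C)C`: 18500 nM

In an ADME assay on HEp-2 cells (Homo sapiens) for cytotoxicity (a higher number here means that more compound is tolerated, a lower number that less compound is tolerated), compound 2 gives the lower of the two numbers, 18500 nM, while compound 1 stands higher at 178000 nM. Compound 3 `CC(C)CCn1c(Cn2c(=O)n(C(C)C)c3ccccc32)nc2cc(-c3ncon3)ccc21` has not yet been measured. It differs from compound 2 with 1,2,4-oxadiazol-3-yl in place of ethyl on an aromatic carbon. Going by the values given here, only one measured step bears on this change, a 9.6-fold lower number from compound 1 to compound 2 (0.98 log units; beyond the scatter), which is beyond the scatter and concerns the group that compound 3 also alters. The entering ring carries hetero atoms, as the acetamido group of compound 1 does, so a rise from compound 2 is expected, though smaller than that step. The expected change is a 2.4-fold higher number from compound 2 to compound 3 (0.39 log units; beyond the scatter). Compound 3 is estimated at 45000 nM, with an expected range from 15000 nM to 150000 nM.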

Compound 3, half-maximal cytotoxic concentration: 223000 nM
Compound 3: middle estimate off by 5.0-fold (0.70 log units), on the low side; measured number above the stated range.
By their numbers in this assay, from the lowest: compound 2; then compounds 1 and 3 (each within the scatter of the next).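

In this assay, going by these compounds alone, 1,2,4-oxadiazol-3-yl in place of ethyl on this aromatic carbon gives a 12-fold higher number from compound 2 to compound 3 (1.08 log units; beyond the scatter) and so reaches well beyond the scatter, which the earlier compounds could not show for a ring at this position. The same ring in place of acetamidomethyl gives a 1.3-fold higher number from compound 1 to compound 3 (0.10 log units; within the scatter) within the scatter, so these two groups cannot be told apart in this assay, and compound 2 with ethyl stands alone at the lower number, while the ring entering here has 0 hydrogen-bond donors. Nothing available explains why this position responds in this way.

The compounds shown leave open whether a simple amine, a carboxylic acid or a longer alkyl chain here would side with ethyl or with the two higher compounds. They also leave open whether another five-membered aromatic ring would match 1,2,4-oxadiazol-3-yl.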